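Swapping the Ring Substitution Pattern on the Hydrazone Arm

A few compounds are considered here, and "the series" means these few. Any claim that something is new, unique, unknown or untested is made for them only; others in the source may bear on it.

Compound 1 `COc1ccc(/C=N/NC(=O)c2ccc(-c3nc4ccccc4s3)cc2)c(O)c1` is measured in an assay on isolated protein for inhibition of Maltase-glucoamylase (Homo sapiens), with a stated time of 15 min (on this read-out lower numbers stand for stronger inhibition and higher numbers for weaker inhibition), where compound 1 gives 6970 nM. That is the lowest of the two numbers recorded, though its neighbour compound 3 `O=C(N/N=C/c1ccccc1)c1ccc(-c2nc3ccccc3s2)cc1` gives 8050 nM, and the change a 1.2-fold higher number from compound 1 to compound 3 (0.06 log units; within the scatter) lies within the scatter. Compound 2 `COc1ccc(/C=N/NC(=O)c2ccc(-c3nc4ccccc4s3)cc2)cc1O` is reported in this assay as "not active" (no number reported), so it offers no number for comparison. Compound 4 `COc1cc(/C=N/NC(=O)c2ccc(-c3nc4ccccc4s3)cc2)ccc1O` has not been measured; compared with compound 1 the change is 4-hydroxy-3-methoxyphenyl in place of 2-hydroxy-4-methoxyphenyl on a carbon with a double bond to nitrogen. Within the data shown here, only one measured step bears on this: the step from compound 1 to compound 3 shows that replacing the whole 2-hydroxy-4-methoxyphenyl group with phenyl hardly moves the number, so the hydroxy and methoxy groups in their original places contribute little that can be seen above the scatter. The outcome for compound 2, which carries its two oxygen groups in yet another arrangement, warns that a rearranged pattern may lose activity altogether. The step from compound 1 to compound 4 is therefore expected to be a 1.4-fold higher number from compound 1 to compound 4 (0.16 log units; within the scatter), a modest weakening in this assay. Compound 4 is estimated at 10000 nM, within a range from 4000 nM to 30000 nM.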

Compound 4, half-maximal inhibitory concentration: 53300 nM
Compound 4: middle estimate off by 5.3-fold (0.73 log units), on the low side, and the stated range ends below it.
By their numbers in this assay, from the lowest: compounds 1 and 3 (each within the scatter of the next); then compound 4.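

On the carbon with a double bond to nitrogen, the arrangement of the two oxygen groups clearly matters in this assay: moving them to give 4-hydroxy-3-methoxyphenyl, with the same atoms joined differently, produces a 7.6-fold higher number from compound 1 to compound 4 (0.88 log units; beyond the scatter). The unsubstituted phenyl also outperforms this arrangement, with a 6.6-fold higher number from compound 3 to compound 4 (0.82 log units; beyond the scatter), so these two groups are not neutral here, even though compound 1 and compound 3 lie within the scatter of each other. No measurement shown here gives a reason for this loss.

As far as these compounds go, it remains open whether the hydroxy or the methoxy group drives the loss when either stands alone on the phenyl ring. Also open, from the compounds shown here alone, is how a phenyl ring carrying an amine or a carboxylic acid would compare at this position.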